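The compounds below may be only part of what the source reports. "The series", "measured", "known", "first", "only" and "open" are said of these compounds alone.

Compound 2 `O=S(=O)(NCCCNCc1ccc(Cl)c(Cl)c1)c1cc(C(F)(F)F)cc(C(F)(F)F)c1` gives 5600 nM in a functional assay on PANC-1 cells (Homo sapiens) for inhibition, read by MTT assay, with a stated time of 72 h (on this read-out lower numbers stand for stronger inhibition of growth and higher numbers for weaker inhibition of growth), and stands highest of the two numbers in hand, while compound 1 `O=S(=O)(NCCCCNCc1ccc(Br)cc1)c1cc(C(F)(F)F)cc(C(F)(F)F)c1` gives 2200 nM, the difference being a 2.5-fold higher number from compound 1 to compound 2 (0.41 log units; beyond the scatter). Compound 3 `CN(CCCNS(=O)(=O)c1cc(C(F)(F)F)cc(C(F)(F)F)c1)Cc1ccccc1` returns only a limit, > 50000 nM. Both an at least 22-fold higher number from compound 1 to compound 3 (1.35 log units; beyond the scatter) and an at least 8.9-fold higher number from compound 2 to compound 3 (0.95 log units; beyond the scatter) run into (the limit of > 50000 nM in this assay, at which 1 of the 3 values shown sits). Compound 4 `O=S(=O)(NCCCNCc1cccc2ccccc12)c1cc(C(F)(F)F)cc(C(F)(F)F)c1` carries naphthalen-1-yl in place of 3,4-dichlorophenyl on a saturated chain carbon bound to an amine nitrogen. Among the compounds with values here, of the measured steps, only the one from compound 1 to compound 2 swaps one aromatic group bound to the amine for another, and that step was modest; the two steps ending at compound 3 install benzyl(methyl)amino and are a different kind of change. A modest step in this assay, with the direction open, is therefore expected. Compound 4 is estimated at 4000 nM, ranging from 1500 nM to 12000 nM. This expectation means a 1.4-fold lower number from compound 2 to compound 4 (0.15 log units; within the scatter).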

Compound 4, concentration for 50% growth inhibition: 2700 nM
Beside the measured number, compound 4's estimate is 1.5-fold (0.17 log units) above it, within the range that was stated.
By their numbers in this assay, from the lowest: compounds 1 and 4 (each within the scatter of the next); then compound 2. At a limit, above all of these: compound 3.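

Placing naphthalen-1-yl in place of 3,4-dichlorophenyl on a saturated chain carbon bound to an amine nitrogen gives a 2.1-fold lower number from compound 2 to compound 4 (0.32 log units; beyond the scatter) in this assay. This step changes only the aromatic group, and it shows that a group of carbon only, with two six-membered aromatic rings, can replace the dichlorinated ring without loss of growth inhibition. The evidence in hand gives no cause for this step. Still open, going by these compounds, is how naphthalen-2-yl or a pyridine ring would read at this place, and whether a longer chain would change the number for compound 4.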